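This account rests on a few compounds, and the source may have more. Where it says the series, first, only, none or still open, it means among the compounds named here.

Within the data shown here, in an ADME assay on MT4 cells (Homo sapiens) for cytotoxicity, read by MTT assay, with a stated time of 96 h (on this read-out higher numbers stand for lower toxicity in this test and lower numbers for higher toxicity in this test), compound 1 (`Oc1ccc(-c2nc3cc(C(F)(F)F)ccc3[nH]2)cc1`) gives 17000 nM, the lower of the two numbers so far, and compound 2 (`COc1ccc(-c2nc3cc(C(F)(F)F)ccc3[nH]2)c([N+](=O)[O-])c1`) gives 85000 nM, a gap beyond the usual scatter. Compound 3 (`Fc1ccc(-c2nc3cc(C(F)(F)F)ccc3[nH]2)cc1`) keeps the core of compound 1 but has fluoro in place of hydroxy on an aromatic carbon, para to a large group: fluoro in place of hydroxy on an aromatic carbon. Among the measured compounds shown here, no measured pair isolates this change, so any forecast is loose. A modest rise in this assay is expected, pointing to somewhat lower toxicity in this test. The expected move is a 2.1-fold higher number from compound 1 to compound 3 (0.31 log units; beyond the scatter). For compound 3, the estimated value is 35000 nM, within an expected range of 10000 nM to 100000 nM.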

Compound 3, half-maximal cytotoxic concentration: 22000 nM
Compound 3: the middle estimate sits 1.6-fold (0.20 log units) above what was measured; measured number inside the range.
By their numbers in this assay, from the lowest: compounds 1 and 3 (each within the scatter of the next); then compound 2.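

In this assay, putting fluoro in place of hydroxy on this aromatic carbon, para to a large group, gives a 1.3-fold higher number from compound 1 to compound 3 (0.11 log units; within the scatter). So in this one pair, the hydrogen-bond donor and acceptor counted for hydroxy can leave this position with no readable shift in the number. Nothing measured here explains why the two groups read alike.

As far as these compounds go, whether an amine, a carboxylic acid or a longer chain at this position would stay as close to compound 1 remains open. A single pair cannot show how widely this holds.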